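Replacing the aryl group on the core nitrogen: compound 4

The source may report more compounds than this note shows. Statements on the series, on what has been measured and on what is new or still open speak of the compounds shown alone.

Three analogues of a shared core have been measured in a functional assay on HT-29 cells (Homo sapiens) for antiproliferative activity, read by MTT assay, with a stated time of 72 h; on this read-out lower numbers stand for stronger inhibition and higher numbers for weaker inhibition. Compound 2 `CCCNC(=O)c1cc(Oc2ccc(NC(=O)c3cc4cccnc4n(-c4ccc(F)cc4)c3=O)cc2)ccn1` gives 84 nM, compound 3 `CCCNC(=O)c1cc(Oc2ccc(NC(=O)c3cc4cccnc4n(-c4ccc(C(F)(F)F)cc4Cl)c3=O)cc2)ccn1` gives 1960 nM, and compound 1 `CCNC(=O)c1cc(Oc2ccc(NC(=O)c3cc4cccnc4n(-c4ccc(F)c(Cl)c4)c3=O)cc2)ccn1` gives 2600 nM. Compound 3 thus stands second highest of the three numbers; its nearest neighbour is compound 1, within the scatter, and its furthest is compound 2, far beyond it.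

Compound 4 `CCCNC(=O)c1cc(Oc2ccc(NC(=O)c3cc4cccnc4n(-c4ccc(F)c(Cl)c4)c3=O)cc2)ccn1` is compound 3 with a single change: 3-chloro-4-fluorophenyl in place of 2-chloro-4-(trifluoromethyl)phenyl on an aromatic nitrogen. Among the measured compounds shown here, the one measured step touching this position is a 23-fold higher number from compound 2 to compound 3 (1.37 log units; beyond the scatter), which shows that the aryl group on that nitrogen can move this assay strongly. For the measured compounds named here, no step from compound 3 to compound 4 has been measured, but compound 1, which carries the same 3-chloro-4-fluorophenyl group on that nitrogen with a different amide substituent, gives a number close to that of compound 3. Taken together, a modest lowering is expected, because the propyl amide in compound 2 gave 84 nM while the 3-chloro-4-fluorophenyl group in compound 1 gave 2600 nM. The estimated step is a 1.6-fold lower number from compound 3 to compound 4 (0.21 log units; within the scatter). For compound 4 the expected value in this assay is 1200 nM, with a range from 200 nM to 6000 nM.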

Compound 4, half-maximal inhibitory concentration: 920 nM
Estimate against measurement, compound 4: 1.3-fold (0.12 log units) above; measured number inside the range.
By their numbers in this assay, from the lowest: compound 2; then compound 4; then compounds 3 and 1 (each within the scatter of the next).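

In this assay, the effect of chloro on the aryl group can now be read with the propyl amide held fixed: chloro in place of hydrogen on an aromatic carbon gives an 11-fold higher number from compound 2 to compound 4 (1.04 log units; beyond the scatter), so this single change on the 4-fluorophenyl group costs a large part of what was lost in going to the 2-chloro-4-(trifluoromethyl)phenyl group. Exchanging that group for 3-chloro-4-fluorophenyl gives a 2.1-fold lower number from compound 3 to compound 4 (0.33 log units; beyond the scatter), a modest recovery that leaves compound 4 well short of compound 2. The amide chain matters as well, since methyl in place of hydrogen on a saturated chain carbon, which turns the ethyl amide into the propyl amide, gives a 2.8-fold lower number from compound 1 to compound 4 (0.45 log units; beyond the scatter) with the aryl group unchanged.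

Still open, on these data alone, is whether a methoxy group or an amine on this aryl ring, or a butyl chain on the amide, would bring the number back towards that of compound 2. Nothing available here accounts for why any of these changes moves the number as it does.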